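The compounds below may be only part of what the source reports. "The series", "measured", "known", "first", "only" and "open" are said of these compounds alone.

Compound 1 `C#CCSc1nc(Sc2ccccn2)c(C#N)c(-c2cc(OC)c(OC)c(OC)c2)n1`: > 10000 nM
Compound 2 `C=CC(=O)Nc1ccccc1CN(C(=O)Nc1cccc(C(F)(F)F)c1)C1CCN(C(C)CCC)CC1`: 25300 nM
Compound 3 `C#CCSc1nc(Sc2nccs2)c(C#N)c(-c2ccc(Cl)cc2)n1`: 3620 nM

All three readings come from a functional assay on PC-3 cells (Homo sapiens) for antiproliferative activity, read by MTT assay, with a stated time of 72 h; a lower number here means a stronger inhibitor, a higher number a weaker inhibitor. Compound 1 stands at the limit of > 10000 nM in this assay, at which 1 of the 3 values shown sits, and this reading is a limit, not a number. Compound 4 `C#CCSc1nc(Sc2nc(C)cs2)c(C#N)c(-c2cc(OC)c(OC)c(OC)c2)n1` keeps the core of compound 1 and changes one group: 4-methyl-1,3-thiazol-2-yl in place of pyridin-2-yl on a sulfur. In words, 4-methyl-1,3-thiazol-2-yl takes the place of pyridin-2-yl on a sulfur.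

Going by the values given here, no measured pair differs in one place, so the size of this step in this assay has no direct precedent. Compound 3 also carries a five-membered aromatic ring with 2 hetero atoms on a sulfur and gives 3620 nM, but it differs from compound 4 in other places too. Compound 2 is too different in structure to guide the estimate. The expectation is therefore a modest move toward stronger inhibition, and a second limit reading remains possible. The estimated step is an at least 1.4-fold lower number from compound 1 to compound 4 (0.15 log units; that floor lies within the scatter). For compound 4 the expected value is 7000 nM, with an estimated range of 2000 nM to 20000 nM.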

Compound 4, half-maximal inhibitory concentration: > 20000 nM
Compound 4: no number, only a limit (the forecaster's own chance of this, stated with the estimate: 45%); middle value at least 2.8-fold (0.45 log units) from the limit.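

In this assay, compound 1 and compound 4 both give limits rather than numbers, and no step can be read between them. On these data alone, it remains open how far 4-methyl-1,3-thiazol-2-yl in place of pyridin-2-yl on a sulfur shifts the value on the shared core.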